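The source may hold more compounds than are shown below. What is called first, only, known or untested is meant among the compounds shown, and "the series" means these compounds.

Compound 1 (`Cc1ccc(S(=O)(=O)Nc2cc(SCC(=O)N[C@@H](CC(C)C)B(O)O)c(O)c3ccccc23)cc1`) gives 12800 nM
Compound 2 (`CC(C)C[C@H](NC(=O)CSc1cc(NS(=O)(=O)c2cccs2)c2ccccc2c1O)B(O)O`) gives 9450 nM

Within the data shown here, in a functional assay on MCF7 cells (Homo sapiens) for antiproliferative activity, read by sulforhodamine B assay, with a stated time of 72 h (on this read-out higher numbers stand for weaker inhibition and lower numbers for stronger inhibition), compound 2 stands within the scatter of compound 1, the only other compound measured. Compound 3 (`CC(=O)Nc1ccc(S(=O)(=O)Nc2cc(SCC(=O)N[C@@H](CC(C)C)B(O)O)c(O)c3ccccc23)cc1`) carries 4-acetamidophenyl in place of thiophen-2-yl on a sulfonyl sulfur. Among the measured compounds shown here, the one measured change at this place, thiophen-2-yl in place of 4-methylphenyl (a 1.4-fold lower number from compound 1 to compound 2 (0.13 log units; within the scatter)), stayed within the scatter. For the measured compounds named here, with only that step to go on, an estimated step (a 1.2-fold higher number from compound 2 to compound 3 (0.07 log units; within the scatter)) within the scatter is expected. Compound 3 is estimated at 11000 nM (expected range 5000 nM to 25000 nM).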

Compound 3, half-maximal inhibitory concentration: 8660 nM
The estimate for compound 3 lay 1.3-fold (0.10 log units) above the measured number; the range from low to high includes it.
By their numbers in this assay, from the lowest: compounds 3, 2 and 1 (each within the scatter of the next).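

In this assay, 4-acetamidophenyl, with 10 heavy atoms and a hydrogen-bond donor, can stand on the sulfonyl sulfur in place of thiophen-2-yl, with 5 heavy atoms and no donor, and the result stays within the scatter (a 1.1-fold lower number from compound 2 to compound 3 (0.04 log units; within the scatter)). Acetamido in place of methyl on an aromatic carbon also stays within the scatter (a 1.5-fold lower number from compound 1 to compound 3 (0.17 log units; within the scatter)). Nothing measured here gives a reason for this insensitivity. Still open, going by these compounds, is whether an amine or a carboxylic acid on that aromatic ring would move the number beyond the scatter.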